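Sulfonyl aryl change to 4-methylphenyl on the shared core

The source may hold more compounds than are shown below. What is called first, only, known or untested is meant among the compounds shown, and "the series" means these compounds.

Measured so far:
- compound 1 `COc1ccc(-c2cc(=O)c3c(OC)cc(OC)cc3n2S(=O)(=O)c2ccc(C#N)cc2)cc1`; in a functional assay on KOPN-8 cells (Homo sapiens) for antiproliferative activity, with a stated time of 72 h (on this read-out higher numbers stand for an effect only at larger amounts of compound and lower numbers for an effect already at smaller amounts), compound 1 gives only the assay limit > 17200 nM.
- compound 2 `COc1ccc(-c2cc(=O)c3c(OC)cc(OC)cc3n2S(=O)(=O)c2c(F)c(F)c(F)c(F)c2F)cc1`; in this assay compound 2 gives only the assay limit > 34400 nM.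

Compound 2 stands at a limit, and the other value shown is a limit as well, so no order between the two can be read. Among the compounds with values here, the single measured step, a step that the two limits leave unreadable from compound 1 to compound 2, stays unreadable between the limit of > 17200 nM in this assay, at which 1 of the 2 values shown sits, and (the limit of > 34400 nM in this assay, at which 1 of the 2 values shown sits).

Compound 3 `COc1ccc(-c2cc(=O)c3c(OC)cc(OC)cc3n2S(=O)(=O)c2ccc(C)cc2)cc1` differs from compound 2 by 4-methylphenyl in place of 2,3,4,5,6-pentafluorophenyl on a sulfonyl sulfur. No readable measured step bears on this change, so in this assay no step beyond the scatter is foreseen. The expected step is an at least 1.1-fold lower number from compound 2 to compound 3 (0.05 log units; that floor lies within the scatter). Compound 3 is estimated at about 30000 nM, within 5000 nM to 100000 nM, quite possibly again only a limit.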

Compound 3, half-maximal effective concentration: > 44800 nM
Compound 3: a limit, no number; the forecaster's own chance of this, stated with the estimate: 75%; middle value at least 1.4-fold (0.17 log units) away from the limit.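

In this assay compound 3 gives only the limit > 44800 nM. Within the data shown here, with compound 1, compound 2 and compound 3 all at limits, no step among them can be read. As far as these compounds go, whether any aryl group on the sulfonyl sulfur of the shared core gives a numerical value in this assay stays open.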